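A positional fluorine swap on the amide of compound 1

The compounds below may be only part of what the source reports. "The series", "measured", "known", "first", "only" and "open" are said of these compounds alone.

Compound 1 `O=C(c1ccc(F)cc1)N1CCc2nc(COc3cccc(F)c3)oc2C1` is the reference point here. In a functional assay on HEK293 cells for positive allosteric modulation of metabotropic glutamate receptor 5 (Homo sapiens), read by calcium flux (on this read-out higher numbers stand for larger maximal responses and lower numbers for smaller maximal responses), compound 1 gives 78%, the highest of the three numbers. Compound 2 `O=C(c1ccc(F)cc1)N1CCc2nc(COc3ccc(F)cc3)oc2C1` gives 73%, and the step of a number 5 percentage points lower from compound 1 to compound 2 (within the scatter) lies within the scatter. Compound 3 `O=C(c1ccc(F)cc1)N1CCc2nc(COc3cccnc3)oc2C1` gives 40%, and the steps of a number 38 percentage points lower from compound 1 to compound 3 (beyond the scatter) and a number 33 percentage points lower from compound 2 to compound 3 (beyond the scatter) are both large. Compound 4 `O=C(c1cccc(F)c1)N1CCc2nc(COc3cccc(F)c3)oc2C1` differs from compound 1 in another place: 3-fluorophenyl in place of 4-fluorophenyl on a carbonyl carbon. Among the measured compounds shown here, no measured step changes the group on the carbonyl carbon, so nothing bears directly on it; the only comparable move of a fluorine, between compound 1 and compound 2, stayed within the scatter. Compound 4 is therefore expected to show a step of a number 4 percentage points lower from compound 1 to compound 4 (within the scatter), no change beyond the scatter. The estimate for compound 4 is 74%, ranging from 55% to 92%.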

Compound 4, largest response reached (reported as percent of maximum), in percent of the reference or control that the assay uses: 75%
Estimate against measurement, compound 4: 1 percentage points below; low and high end bracket the measured number.
By their numbers in this assay, from the lowest: compound 3; then compounds 2, 4 and 1 (each within the scatter of the next).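

In this assay, 3-fluorophenyl in place of 4-fluorophenyl on a carbonyl carbon gives a number 3 percentage points lower from compound 1 to compound 4 (within the scatter). Among the compounds shown here, the earlier steps all changed the group on an oxygen on a saturated carbon, so this is the first reading at the carbonyl carbon, and there too a moved fluorine stays within the scatter. Nothing shown explains this result. What the compounds leave open is whether this position accepts more than a moved fluorine. From the compounds shown here alone, the effect of a pyridin-3-yl, an unsubstituted phenyl or a methoxyphenyl on the carbonyl carbon remains unknown.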